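The source may report more compounds than this note shows. Statements on the series, on what has been measured and on what is new or still open speak of the compounds shown alone.

Measured compounds in a functional assay on HT-29 cells (Homo sapiens) for cytotoxicity, read by XTT assay, with a stated time of 72 h; on this read-out lower numbers stand for stronger inhibition and higher numbers for weaker inhibition:

compound 1 `COc1ccc(C(=O)c2cc(OC)c(OC)c(OC)c2)cc1[N+](=O)[O-]`: 2900 nM
compound 2 `COc1ccc(Cc2ccc(OC)c(OC)c2OC)cc1N`: 330 nM
compound 3 `COc1ccc(Cc2ccc(OC)c(OC)c2OC)cc1[N+](=O)[O-]`: 2900 nM

Compound 3 and compound 2 differ in one place, (amino in place of nitro on an aromatic carbon); the step is an 8.8-fold lower number from compound 3 to compound 2 (0.94 log units; beyond the scatter). Compound 1 stands level with compound 3 at the digits given, within the scatter, and the difference between the two cores is not broken down here.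

Compound 4 `COc1ccc(C(=O)c2cc(OC)c(OC)c(OC)c2)cc1N` is not yet measured. It differs from compound 1 by amino in place of nitro on an aromatic carbon, the same change seen in the measured pair. For compound 4 the expected step is a 7.3-fold lower number from compound 1 to compound 4 (0.86 log units; beyond the scatter), set beside an 8.8-fold lower number from compound 3 to compound 2 (0.94 log units; beyond the scatter) and read from compound 1 at 2900 nM; the unlike cores keep this an expectation only. Compound 4 is estimated at 400 nM in this assay. For compound 4 the expected range is 150 nM to 1200 nM.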

Compound 4, half-maximal inhibitory concentration: 32 nM
Compound 4: the middle estimate sits 13-fold (1.10 log units) above what was measured, and the stated range ends above it.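

Amino in place of nitro gives a lower number on both cores in this assay, and on the core of compound 1 the step is a 91-fold lower number from compound 1 to compound 4 (1.96 log units; beyond the scatter). The direction of the change carries from one core to the other, but its size does not: the same change on two cores in this assay, an 8.8-fold lower number (0.94 log units; beyond the scatter) from compound 3 to compound 2 and a 91-fold lower number (1.96 log units; beyond the scatter) from compound 1 to compound 4, 10-fold (1.01 log units) apart, beyond the scatter of two such steps. Two cores cannot show what size the step would take on a further core, and the two shown differ in more than one place, leaving it untold which difference goes with the larger step.

Open, going by these compounds, is whether another group at this place, such as a hydroxyl, an acetamide or a dimethylamino group, would give a number like that of amino.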